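The source may report more compounds than this note shows. Statements on the series, on what has been measured and on what is new or still open speak of the compounds shown alone.

Measured so far in a functional assay on U-87MG ATCC cells for antiproliferative activity against U-87 MG (Homo sapiens), read by MTT assay, with a stated time of 48 h; a higher number here means a weaker inhibitor, a lower number a stronger inhibitor:
Compound 1 `Cc1nc(-c2ccc(Cl)cc2)sc1C(=O)CSc1nc(-c2cccc(Cl)c2)c(C#N)c(=O)[nH]1`: 40100 nM
Compound 2 `COc1ccc(-c2nc(SCC(=O)c3sc(-c4ccc(Cl)cc4)nc3C)[nH]c(=O)c2C#N)cc1`: 35500 nM
Compound 3 `COc1ccc(-c2nc(SCC(=O)c3sc(-c4ccc(Cl)cc4)nc3C)[nH]c(=O)c2C#N)cc1OC`: 38600 nM

Compound 3 lies within the scatter of both other compounds, with a 1.0-fold lower number from compound 1 to compound 3 (0.02 log units; within the scatter) and a 1.1-fold higher number from compound 2 to compound 3 (0.04 log units; within the scatter) as its steps, so the three values give no order.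

Compound 4 `COc1cccc(-c2nc(SCC(=O)c3sc(-c4ccc(Cl)cc4)nc3C)[nH]c(=O)c2C#N)c1` follows from compound 3 by hydrogen in place of methoxy on an aromatic carbon and so carries 3-methoxyphenyl instead of 3,4-dimethoxyphenyl. The closest measured change is the opposite kind of swap at the other methoxy of compound 3, where a 1.1-fold higher number from compound 2 to compound 3 (0.04 log units; within the scatter) is a step within the scatter. That makes it an indirect guide only. Exchanging the whole aryl group gave a similarly small result, with a 1.1-fold lower number from compound 1 to compound 2 (0.05 log units; within the scatter) as the step to 4-methoxyphenyl. Among the compounds with values here, no measured step in these three compounds leaves the scatter, so no step beyond the scatter is expected in this assay for this change. The expected step is a 1.0-fold lower number from compound 3 to compound 4 (0.02 log units; within the scatter) and is estimated to stay within the scatter. For compound 4 the estimated value is 37000 nM with an expected range from 22000 nM to 60000 nM around it.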

Compound 4, half-maximal inhibitory concentration: 41000 nM
Beside the measured number, compound 4's estimate is 1.1-fold (0.04 log units) below it; measured number inside the range.
By their numbers in this assay, from the lowest: compounds 2, 3, 1 and 4 (each within the scatter of the next).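

In this assay, hydrogen in place of the methoxy that stands ortho to a methoxy group and para to a large group, turning 3,4-dimethoxyphenyl into 3-methoxyphenyl, gives a 1.1-fold higher number from compound 3 to compound 4 (0.03 log units; within the scatter) and so adds a removal to the addition of methoxy already read at the other methoxy position. The single methoxy placement can now be read as well: 3-methoxyphenyl in place of 4-methoxyphenyl gives a 1.2-fold higher number from compound 2 to compound 4 (0.06 log units; within the scatter) and methoxy in place of chloro gives a 1.0-fold higher number from compound 1 to compound 4 (0.01 log units; within the scatter) as the two further steps, so neither the place of the methoxy nor its exchange for chloro separates these compounds, and all four stand without an order in this read-out. No supporting data bear on this result.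

Still open, going by these compounds, is whether an amine or a carboxylic acid on this aryl group would give a step beyond the scatter. All four compounds share the rest of the core, so the effect of a change there, such as a longer chain in place of its methyl, cannot be read from them.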